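The source may report more compounds than this note shows. Statements on the series, on what has been measured and on what is new or still open speak of the compounds shown alone.

Compound 1 `CC1(Cc2ccccc2)CC(S(=O)(=O)c2ccc(F)cc2)=C(c2ccc(/C(N)=N/O)cc2)O1` — in an ADME assay on cells (Peritoneal macrophage, Mus musculus, strain Balb/c) for cytotoxicity, read by resazurin assay, with a stated time of 72 h (on this read-out lower numbers stand for higher toxicity in this test and higher numbers for lower toxicity in this test), compound 1 gives 102000 nM
Compound 2 `CCC1(CC)CC(S(=O)(=O)c2ccc(F)cc2)=C(c2ccc(/C(N)=N/O)cc2)O1` — compound 2 gives 91400 nM
Compound 3 `CC1(Cc2ccc(/C(N)=N/O)cc2)CC(S(=O)(=O)c2ccc(F)cc2)=C(c2ccc(/C(N)=N/O)cc2)O1` — compound 3 gives 42200 nM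

Compound 3 stands lowest of the three numbers in this assay; compound 2 sits nearest, a step beyond the scatter above it, and compound 1 sits furthest, also beyond the scatter. Compound 4 `CC1(Cc2cccc([N+](=O)[O-])c2)CC(S(=O)(=O)c2ccc(F)cc2)=C(c2ccc(/C(N)=N/O)cc2)O1` has not yet been measured in this assay. It differs from compound 3 in one place: a group of 9 heavy atoms (6 carbon, 1 nitrogen, 2 oxygen; one six-membered aromatic ring of carbon only) in place of a group of 10 heavy atoms (7 carbon, 2 nitrogen, 1 oxygen; one six-membered aromatic ring of carbon only), on a saturated chain carbon bound to a saturated ring carbon. Within the data shown here, only one measured step bears on this change. From compound 1 to compound 3 the amidoxime-bearing phenyl replaced a plain benzyl group, and a 2.4-fold lower number from compound 1 to compound 3 (0.38 log units; beyond the scatter). Compound 4 removes that amidoxime-bearing phenyl again and carries a 3-nitrophenyl in its place, so compound 4 resembles compound 1 more than compound 3 does. The number for compound 4 is therefore expected to move back upward in this assay, most likely by a modest step toward the value of compound 1, though a result within the scatter of compound 3 cannot be excluded. The 3-nitrophenyl has no measured counterpart among these compounds. Compound 4 is estimated at 80000 nM, with a range from 35000 nM to 160000 nM, meaning an expected step of a 1.9-fold higher number from compound 3 to compound 4 (0.28 log units; within the scatter).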

Compound 4, half-maximal cytotoxic concentration: 86600 nM
Compound 4: the middle estimate sits 1.1-fold (0.03 log units) below what was measured; measured number inside the range.
By their numbers in this assay, from the lowest: compound 3; then compounds 4, 2 and 1 (each within the scatter of the next).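

In this assay, at this saturated chain carbon bound to a saturated ring carbon, 3-nitrophenyl in place of the amidoxime-bearing phenyl gives a 2.1-fold higher number from compound 3 to compound 4 (0.31 log units; beyond the scatter). Set against the plain benzyl group of compound 1, the nitro in place of hydrogen on an aromatic carbon gives a 1.2-fold lower number from compound 1 to compound 4 (0.07 log units; within the scatter), so this substituent on the ring, unlike the amidoxime of compound 3, leaves the number within the scatter of the unsubstituted compound. The lower number of compound 3 is therefore not shared by every substituent on this ring, and nothing available here accounts for the difference between the two groups.

The compounds shown leave open whether the lower number of compound 3 is particular to the amidoxime or would also appear with other groups on the same ring, such as an amine or a carboxylic acid. They also leave open whether the nitro would give a similar number at another place on that ring, and whether a longer chain linking the ring to the core would change the picture.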